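The source may report more compounds than this note shows. Statements on the series, on what has been measured and on what is new or still open speak of the compounds shown alone.

Two compounds of the series carry numbers in a functional assay on OVCAR-8 cells (Homo sapiens) for inhibition, read by sulforhodamine B assay, with a stated time of 72 h; on this read-out higher numbers stand for weaker inhibition and lower numbers for stronger inhibition. Compound 1 `CC1=C(Br)C(=O)C(C(C)C)=C(Br)C1=O` gives 3600 nM in this assay. Compound 2 `Cc1cc(O)c(C(C)C)cc1O` gives 8900 nM in this assay, the highest of the two numbers shown; its nearest neighbour is compound 1, whose number is lower by a gap beyond the scatter. The two structures differ in more than one place, so nothing is drawn from that gap about any single change.

Compound 3 `Cc1cc(O)c(C(C)(C)C)cc1O` is not yet measured in this assay. It differs from compound 2 by methyl in place of hydrogen on a saturated chain carbon bound to an aromatic carbon and two saturated chain carbons. The same difference, cut one bond further out, reads as isopropyl to tert-butyl. Among the compounds with values here, no measured pair shares this change, so no step size can be taken from the data for it. The expectation is a step of no more than the scatter, with no direction favoured. The estimated step of a 1.1-fold lower number from compound 2 to compound 3 (0.05 log units; within the scatter) is meant as one within the scatter. Compound 3 is expected to give 8000 nM in this assay. The range for compound 3 is estimated to run from 3500 nM to 20000 nM.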

Compound 3, half-maximal inhibitory concentration: 12200 nM
Estimate against measurement, compound 3: 1.5-fold (0.18 log units) below, within the range that was stated.
By their numbers in this assay, from the lowest: compound 1; then compounds 2 and 3 (each within the scatter of the next).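

In this assay, within the data shown here, the change from isopropyl to tert-butyl reads as a 1.4-fold higher number from compound 2 to compound 3 (0.14 log units; within the scatter), the first step that can be read for a single change. On this one pair, methyl in place of hydrogen on the saturated chain carbon bound to an aromatic carbon and two saturated chain carbons leaves compound 2 and compound 3 inseparable on this read-out, so the position accepts the extra methyl with no step beyond the scatter. Nothing measured on either compound speaks to why the step has this size.

Among these compounds, still open is whether the step stays within the scatter when a group of another kind stands at this position, such as a longer chain, a cyclohexyl group, an amine or a carboxylic acid, since isopropyl and tert-butyl are the only two groups compared here. Also open, on these data alone, is how the same change from isopropyl to tert-butyl reads on the core of compound 1, which differs from compound 2 in more than one place and so gives no single-change comparison.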